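The source may hold more compounds than are shown below. What is called first, only, known or untested is meant among the compounds shown, and "the series" means these compounds.

The measured compounds in a functional assay on Hs-578T cells (Homo sapiens) for inhibition; on this read-out lower numbers stand for stronger inhibition of growth and higher numbers for weaker inhibition of growth:

compound 1 `COc1cc(/C=C/C(=O)c2cccc(-n3cc(-c4ccc(Cl)cc4)[nH]c3=O)c2)cc(OC)c1OC` — 5960 nM
compound 2 `COc1cc(/C=C/C(=O)c2cccc(-n3cc(-c4ccccc4)[nH]c3=O)c2)ccc1O` — 4160 nM
compound 3 `COc1cc(/C=C/C(=O)c2cccc(-n3cc(-c4ccccc4)[nH]c3=O)c2)cc(OC)c1OC` — 3410 nM

Compound 2 stands second highest of the three numbers in this assay; its gap to compound 3 lies within the scatter, and so does its gap to compound 1. Compound 4 `COc1cc(/C=C/C(=O)c2cccc(-n3cc(-c4ccc(Cl)cc4)[nH]c3=O)c2)ccc1O` differs from compound 2 by chloro in place of hydrogen on an aromatic carbon. For the measured compounds named here, one measured step bears on this change: a 1.7-fold lower number from compound 1 to compound 3 (0.24 log units; within the scatter), which is the same exchange run backwards. Read in the forward direction, compound 4 is expected to give a higher number than compound 2, a step of a 1.7-fold higher number from compound 2 to compound 4 (0.23 log units; within the scatter), within the scatter. Compound 4 is therefore estimated at 7000 nM, with a range from 3000 nM to 16000 nM.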

Compound 4, concentration for 50% growth inhibition: 4670 nM
Compound 4: the middle estimate sits 1.5-fold (0.18 log units) above what was measured, within the range that was stated.
By their numbers in this assay, from the lowest: compounds 3, 2, 4 and 1 (each within the scatter of the next).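

In this assay, the exchange of phenyl for 4-chlorophenyl now has a reading on a second core, a 1.1-fold higher number from compound 2 to compound 4 (0.05 log units; within the scatter). Chloro in place of hydrogen at this position, para to a large group, thus stays within the scatter on both cores, where the earlier compounds showed it on only one: the same change on two cores in this assay, a 1.7-fold lower number (0.24 log units; within the scatter) from compound 1 to compound 3 and a 1.1-fold lower number (0.05 log units; within the scatter) from compound 4 to compound 2, 1.6-fold (0.19 log units) apart, within the scatter of two such steps

The compounds shown leave open whether any other group on this aromatic carbon, such as an amine or a carboxylic acid, would give a step beyond the scatter. They also cannot say whether chloro would behave alike on other cores.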